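From Aryl Ketone to Benzyl Ether on a Shared Core

The compounds below may be only part of what the source reports. "The series", "measured", "known", "first", "only" and "open" are said of these compounds alone.

compound 1, `COc1cc(OC)c(-c2coc3cc(OCC=C(C)C)ccc3c2=O)cc1OC`: 1090 nM
compound 2, `COc1cccc(C(=O)Oc2ccc3c(=O)c(-c4cc(OC)c(OC)cc4OC)coc3c2)c1`: > 10000 nM
compound 3, `COc1cc(OC)c(-c2coc3cc(OCC(=O)c4cccc(C(F)(F)F)c4)ccc3c2=O)cc1OC`: > 10000 nM

In a functional assay on B16 cells (Mus musculus) for antiproliferative activity, read by MTT assay, with a stated time of 24 h (a higher number here means a weaker inhibitor, a lower number a stronger inhibitor), compound 1 is the only one of the three to give a number, 1090 nM. For compound 2 the reading is a limit of the assay, > 10000 nM. For compound 3 the reading is likewise a limit, > 10000 nM. Compound 3 therefore stands at the limit of > 10000 nM in this assay, at which 2 of the 3 values shown sit, and nothing more than that limit is known of it.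

Two measured steps start from compound 1 and both reach that limit: an at least 9.1-fold higher number from compound 1 to compound 2 (0.96 log units; beyond the scatter) and an at least 9.1-fold higher number from compound 1 to compound 3 (0.96 log units; beyond the scatter). In each an aryl carbonyl enters and the number rises out of range.

Compound 4, `COc1cc(OC)c(-c2coc3cc(OCc4ccccc4C(F)(F)F)ccc3c2=O)cc1OC`, is the next step from compound 3: 2-(trifluoromethyl)phenyl in place of (3-(trifluoromethyl)phenyl)carbonyl on a saturated chain carbon bound to an oxygen on an aromatic ring. The carbonyl that entered in the step from compound 1 to compound 3 leaves again, while an aromatic ring stays on the saturated chain carbon; compound 4 thus lies between compound 1 and compound 3 in its make-up. A return toward the number of compound 1 is therefore expected, though not necessarily all the way, since compound 1 alone shows what a carbonyl-free ether gives here. Compound 4 is estimated at 3000 nM, in a range from 800 nM to 15000 nM, which is expected to mean an at least 3.3-fold lower number from compound 3 to compound 4 (0.52 log units; beyond the scatter).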

Compound 4, half-maximal inhibitory concentration: 8550 nM
Estimate against measurement, compound 4: 2.9-fold (0.45 log units) below; the range from low to high includes it.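

In this assay, of the compounds with an aromatic ring in the group on that oxygen, compound 4 alone gives a number rather than a limit, and that number still lies well short of the 3-methylbut-2-en-1-yl ether: a 7.8-fold higher number from compound 1 to compound 4 (0.89 log units; beyond the scatter). The two steps to compound 4 from compounds at the limit give only floors, and these fix no size for the change: an at least 1.1-fold lower number from compound 3 to compound 4 (0.06 log units; that floor lies within the scatter), and an at least 1.1-fold lower number from compound 2 to compound 4 (0.06 log units; that floor lies within the scatter). How much the loss of the carbonyl gains therefore stays unmeasured, because the starting points of both steps are limits and not numbers: the limit of > 10000 nM in this assay, at which 2 of the 4 values shown sit.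

The step from compound 3 to compound 4 removes the carbonyl and also swaps 3-(trifluoromethyl)phenyl for 2-(trifluoromethyl)phenyl, so the compounds shown cannot separate the two changes, and a carbonyl-free 3-(trifluoromethyl)phenyl group would be needed to do so. They also leave open whether an unsubstituted phenyl, a methoxy-bearing phenyl, a longer saturated chain or an amine on the same saturated chain carbon would come closer to compound 1.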